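Dimethylhydrazone in place of carboxamide on the shared core

The compounds below may be only part of what the source reports. "The series", "measured", "known", "first", "only" and "open" are said of these compounds alone.

Of the compounds shown here, three of the shared core have been measured in a functional assay on KB cells (Homo sapiens) for cytotoxicity, read by spectrophotometry and crystal violet staining; a lower number here means a stronger inhibitor, a higher number a weaker inhibitor. Compound 1 `CO/N=C/c1c(Cl)n(C2O[C@H](CO)[C@@H](O)[C@H]2O)c2cc(Cl)c(Cl)cc12` gives 70000 nM in this assay. Compound 3 `NC(=O)c1c(Cl)n(C2O[C@H](CO)[C@@H](O)[C@H]2O)c2cc(Cl)c(Cl)cc12` gives 45000 nM in this assay. Compound 2 `N/C(=N\O)c1c(Cl)n(C2O[C@H](CO)[C@@H](O)[C@H]2O)c2cc(Cl)c(Cl)cc12` sits at > 100000 nM, which is a limit of the assay and not a number (the limit of > 100000 nM in this assay, at which 1 of the 3 values shown sits). For the measured compounds named here, compound 3 stands lowest of the two numbers known; its nearest neighbour is compound 1, with a 1.6-fold lower number from compound 1 to compound 3 (0.19 log units; within the scatter), within the scatter, while an at least 2.2-fold lower number from compound 2 to compound 3 (0.34 log units; beyond the scatter) is at least modest.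

Compound 4 `CN(C)/N=C/c1c(Cl)n(C2O[C@H](CO)[C@@H](O)[C@H]2O)c2cc(Cl)c(Cl)cc12` is not yet measured. It differs from compound 3 by a group of 5 heavy atoms (3 carbon, 2 nitrogen; no ring) in place of a group of 3 heavy atoms (1 carbon, 1 nitrogen, 1 oxygen; no ring), on an aromatic carbon. The entering group resembles the group of compound 1 more than the carbamoyl of compound 3, so the step that bears on it most is a 1.6-fold lower number from compound 1 to compound 3 (0.19 log units; within the scatter), read in reverse, which lay within the scatter; an at least 1.4-fold higher number from compound 1 to compound 2 (0.15 log units; that floor lies within the scatter) adds little, since one end of it is only a limit. No step beyond the scatter is therefore expected, if anything a somewhat higher number. For compound 4 the expected value in this assay is 75000 nM, between 30000 nM and 200000 nM. This estimate means an expected 1.7-fold higher number from compound 3 to compound 4 (0.22 log units; within the scatter).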

Compound 4, half-maximal inhibitory concentration: 70000 nM
Compound 4: the middle estimate sits 1.1-fold (0.03 log units) above what was measured; the measured number falls inside the stated range.
By their numbers in this assay, from the lowest: compounds 3, 1 and 4 (each within the scatter of the next). At a limit, above all of these: compound 2.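

On the double-bonded nitrogen, dimethylamino in place of methoxy gives no change at the digits printed from compound 1 to compound 4 (within the scatter) in this assay, so this exchange leaves the read-out where it was at the digits printed. Where the group on the aromatic carbon of the five-membered ring changes from carbamoyl, with 1 hydrogen-bond donor, to a group with 0 hydrogen-bond donors and 5 heavy atoms, the result is a 1.6-fold higher number from compound 3 to compound 4 (0.19 log units; within the scatter); across compounds 1, 3 and 4, neither the loss of that donor nor the larger group separates the compounds in this assay. Compound 2 remains at a limit of the assay and not at a number: the limit of > 100000 nM in this assay, at which 1 of the 4 values shown sits.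

With an at least 1.4-fold lower number from compound 2 to compound 4 (0.15 log units; that floor lies within the scatter), the gap to compound 2 has only a floor and no size, and it gives no reliable order between these two compounds. Whether a carboxylic acid, a nitrile or a primary amine on this aromatic carbon would stay among these values, or would move the number beyond the scatter from compound 3, remains open.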